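The source may report more compounds than this note shows. Statements on the series, on what has been measured and on what is new or still open speak of the compounds shown alone.

Measured compounds in an ADME assay on PC-3 cells (Homo sapiens) for cytotoxicity, read by WST assay, tested at 100 uM; on this read-out lower numbers stand for less inhibition and higher numbers for more inhibition at the one concentration tested (going by the name of the read-out):
- compound 1, `O=C(Nc1cccc(CN2CCCC2)c1)C1CCCN(C(=O)c2cc(C(F)(F)F)cc(C(F)(F)F)c2)C1`: 51%
- compound 2, `O=C(Nc1cccc(Cc2ccccc2)c1)C1CCCN(C(=O)c2cccc(-c3ccco3)c2)C1`: 0%
- compound 3, `O=C(c1ccccc1)c1cccc(C(=O)N2CCCC(C(=O)Nc3ccc(Cl)cc3)C2)c1`: 0%

Among the three numbers, compound 1 stands highest, its value lying beyond the scatter above both compound 2 and compound 3, which show the same number as each other. Among the compounds with values here, no pair of measured compounds differs in a single place, so no measured step is available for reading across.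

Compound 4, `C=CCOc1cccc(NC(=O)C2CCCN(C(=O)c3cc(C(F)(F)F)cc(C(F)(F)F)c3)C2)c1`, is not yet measured. It keeps the core of compound 1 and its bis(trifluoromethyl)benzoyl part; the change is allyloxy in place of (pyrrolidin-1-yl)methyl on an aromatic carbon.

Within the data shown here, with no measured step for this kind of change, and the two compounds carrying a different aromatic amide part both at the bottom of the range, a loss of some size relative to compound 1 is expected rather than a gain, with the step from compound 1 to compound 4 estimated at a number 21 percentage points lower from compound 1 to compound 4 (beyond the scatter). Compound 4 is accordingly expected to give about 30% in this assay, in a range from 5% to 60%.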

Compound 4, a percentage reported as inhibition, at one concentration (the size of the read-out at that concentration, not a potency): 0%
Compound 4: middle estimate off by 30 percentage points, on the high side; measured number outside the range, below it.
By their numbers in this assay, from the lowest: compounds 2, 3 and 4 (each within the scatter of the next); then compound 1.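

Swapping (pyrrolidin-1-yl)methyl for allyloxy on an aromatic carbon, with the shared core and the bis(trifluoromethyl)benzoyl part kept, gives a number 51 percentage points lower from compound 1 to compound 4 (beyond the scatter) in this assay. The core and the bis(trifluoromethyl)benzoyl part therefore do not carry the read-out alone: in this pair, the group at this aromatic carbon decides whether any inhibition appears at the one concentration tested, and compound 4 gives 0%. Nothing measured here bears on the reason for this step.

This single step changes the ring, the nitrogen and the oxygen at once, so it does not show which of them matters. Going by these compounds, an open-chain (dimethylamino)methyl group or a methoxy group at the same carbon would bear on that, and whether other amines restore the read-out remains open.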